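Swapping Methylsulfanyl for Dimethylamino on a Furan-Bearing Nucleoside

This account rests on a few compounds, and the source may have more. Where it says the series, first, only, none or still open, it means among the compounds named here.

Measured in a functional assay on HeLa S3 cells (Homo sapiens) for antiproliferative activity, read by XTT assay, with a stated time of 72 h; on this read-out higher numbers stand for weaker inhibition and lower numbers for stronger inhibition:
- compound 1 `CSc1ncnc2c1c(-c1ccoc1)cn2[C@@H]1O[C@H](CO)[C@@H](O)[C@H]1O`: 5390 nM
- compound 2 `CSc1ncnc2c1c(-c1ccsc1)cn2[C@@H]1O[C@H](CO)[C@@H](O)[C@H]1O`: > 20000 nM

Within the data shown here, compound 1 holds the only true number so far. The entry for compound 2 is a limit of the assay, not a number. The next molecule, compound 3 `CN(C)c1ncnc2c1c(-c1ccoc1)cn2[C@@H]1O[C@H](CO)[C@@H](O)[C@H]1O`, keeps the furan-3-yl group and changes one other group: dimethylamino in place of methylsulfanyl on an aromatic carbon. Among the measured compounds shown here, no measured step covers this swap. For the measured compounds named here, the one measured step, an at least 3.7-fold higher number from compound 1 to compound 2 (0.56 log units; beyond the scatter), changes a different group, so it bears only indirectly, as a sign that a single swap on compound 1 can cost activity in this assay. A modest loss is therefore the best guess, with the number moving upward. The expected change is a 2.2-fold higher number from compound 1 to compound 3 (0.35 log units; beyond the scatter). For compound 3 the estimate is 12000 nM, with an expected range of 4000 nM to 20000 nM.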

Compound 3, half-maximal inhibitory concentration: 9060 nM
Estimate against measurement, compound 3: 1.3-fold (0.12 log units) above; measured number inside the range.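

In this assay, putting dimethylamino in place of methylsulfanyl gives a 1.7-fold higher number from compound 1 to compound 3 (0.23 log units; within the scatter). Among these compounds, this is the first reading at this position, on an aromatic carbon of a six-membered aromatic ring with 2 nitrogen, and with the furan-3-yl group held fixed the two groups cannot be told apart here, even though one brings nitrogen and the other sulfur. The earlier step showed a clear effect only at the furan-3-yl group, and nothing in the data shown explains why this swap leaves the two compounds indistinguishable.

As far as these compounds go, what a plain amino group, a methoxy group or a longer alkyl chain would do at this position stays open. From the compounds shown here alone, it is also open whether dimethylamino would read the same way alongside thiophen-3-yl instead of furan-3-yl.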